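The source may report more compounds than this note shows. Statements on the series, on what has been measured and on what is new or still open speak of the compounds shown alone.

Compound 3 `CCOC(=O)c1cn(C)c2cc(Cl)ccc2c1=O` stands with the highest number among the two finite values in a functional assay on HEp-2 cells (Homo sapiens) for cytotoxicity, read by MTT assay, with a stated time of 24 h (a lower number here means a stronger inhibitor, a higher number a weaker inhibitor), giving 25000 nM; compound 1 `CCOC(=O)c1cn(CCCc2ccccc2)c2cc(Cl)ccc2c1=O` gives 7630 nM. Compound 2 `C=CCn1cc(C(=O)OCC)c(=O)c2ccc(Cl)cc21` reaches only the limit > 50000 nM in this assay. Compound 4 `CCCCn1cc(C(=O)OCC)c(=O)c2ccc(Cl)cc21` differs from compound 3 by propyl in place of hydrogen on a saturated chain carbon bound to an aromatic nitrogen. Two measured steps at this position bear on it: a 3.3-fold higher number from compound 1 to compound 3 (0.52 log units; beyond the scatter), and an at least 2.0-fold lower number from compound 2 to compound 3 (0.30 log units; that floor lies within the scatter), whose floor lies within the scatter. Among the measured compounds shown here, a chain of this size without a ring has no direct precedent here, so compound 4 is expected to move by about a 1.2-fold higher number from compound 3 to compound 4 (0.08 log units; within the scatter) in this assay. Compound 4 is estimated at 30000 nM, with a range from 10000 nM to 100000 nM.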

Compound 4, half-maximal inhibitory concentration: 35500 nM
The estimate for compound 4 lay 1.2-fold (0.07 log units) below the measured number, within the range that was stated.
By their numbers in this assay, from the lowest: compound 1; then compounds 3 and 4 (each within the scatter of the next). At a limit, above all of these: compound 2.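

Propyl in place of hydrogen on a saturated chain carbon bound to an aromatic nitrogen leaves the number within the scatter, with a 1.4-fold higher number from compound 3 to compound 4 (0.15 log units; within the scatter), so a longer open chain alone does not separate these two compounds. Phenyl at the end of the chain does separate them, with a 4.7-fold higher number from compound 1 to compound 4 (0.67 log units; beyond the scatter), which ties the lower number of compound 1 to the phenyl rather than to chain length alone. The step of an at least 1.4-fold lower number from compound 2 to compound 4 (0.14 log units; that floor lies within the scatter) cannot be read, because compound 2 stands at a limit: the limit of > 50000 nM in this assay, at which 1 of the 4 values shown sits.

The compounds shown leave open whether a phenyl on a shorter chain would keep this lower number. They also leave open how an amine or a carboxylic acid at the chain end would read.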